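This account rests on a few compounds, and the source may have more. Where it says the series, first, only, none or still open, it means among the compounds named here.

Measured compounds:
compound 1, `CCOC(=O)c1c(-c2c(Cl)c3ccccc3oc2=O)nn(-c2ccccc2)c1C(=O)OCC`, gives 100000 nM in a functional assay on HeLa cells (Homo sapiens) for cytotoxicity, read by MTT assay, with a stated time of 48 h; a lower number here means a stronger inhibitor, a higher number a weaker inhibitor.
compound 2, `CCOC(=O)c1c(-c2c(Cl)c3ccccc3oc2=O)nn(-c2cccc(C)c2)c1C(=O)OCC`, gives 30000 nM in this assay.
compound 3, `COC(=O)c1c(-c2cc3ccccc3oc2=O)nn(-c2ccccc2)c1C(=O)OC`, gives 35000 nM in this assay.

Within the data shown here, compound 1 and compound 2 share one core, and the single change between them is methyl in place of hydrogen on an aromatic carbon. That change brought a 3.3-fold lower number from compound 1 to compound 2 (0.52 log units; beyond the scatter). Compound 3 has a different core from compound 1; how the two cores differ is not broken down here. Compound 3 and compound 1 are read by their two values alone, which stand some way apart, while compound 3 and compound 2 sit within the usual scatter of each other.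

Compound 4, `COC(=O)c1c(-c2cc3ccccc3oc2=O)nn(-c2cccc(C)c2)c1C(=O)OC`, has not yet been measured. It stands to compound 3 exactly as compound 2 stands to compound 1: the change is methyl in place of hydrogen on an aromatic carbon, and the place line around it is the same word for word as for the pair already measured, so this is the same change made on a second core. The expectation for compound 4 rests on that one earlier step: because compound 2 showed a 3.3-fold lower number from compound 1 to compound 2 (0.52 log units; beyond the scatter), a step of about that size is expected from compound 3 to compound 4, namely a 2.9-fold lower number from compound 3 to compound 4 (0.46 log units; beyond the scatter). Among the measured compounds shown here, only one example of the change is known, so a wider band is kept. Compound 4 is therefore estimated at 12000 nM in this assay, with a range expected from 5000 nM to 35000 nM.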

Compound 4, half-maximal inhibitory concentration: 45000 nM
Estimate against measurement, compound 4: 3.8-fold (0.57 log units) below; measured number above the stated range.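

Moving from phenyl to 3-methylphenyl did not give the same result on the second core: in this assay the change gave a 1.3-fold higher number from compound 3 to compound 4 (0.11 log units; within the scatter), so the clear drop seen on the core of compound 1 did not recur on the core of compound 3. Set side by side, the two results disagree by more than repeated measurements would normally explain, which means the effect of this methyl cannot simply be carried from one core to the other in this series: the same change on two cores in this assay, a 3.3-fold lower number (0.52 log units; beyond the scatter) from compound 1 to compound 2 and a 1.3-fold higher number (0.11 log units; within the scatter) from compound 3 to compound 4, 4.3-fold (0.63 log units) apart, beyond the scatter of two such steps. Among these compounds, this rests on only two matched pairs, however, and it does not show why the results differ or which feature of the two cores matters, since the difference between those cores is not broken down into single changes.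

The compounds shown leave open whether the added methyl would behave the same way on any further core, and whether the result is specific to methyl or would also hold for a methoxy group, an amine or a longer chain such as propyl in the same place on the ring. They also leave open how either core would respond if a carboxylic acid replaced its esters.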